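The source may report more compounds than this note shows. Statements on the series, on what has been measured and on what is new or still open speak of the compounds shown alone.

Compound 2 `CC(C)(C)c1cc(NC(=O)Nc2ccc(Cl)cc2)n(-c2ccc(C#N)cc2)n1` gives 0.8 degrees C in an assay on isolated protein for inhibition of Ephrin type-A receptor 2 (Homo sapiens), read by thermal shift assay, tested at 10 uM (on this read-out lower numbers stand for weaker stabilisation of the target and higher numbers for stronger stabilisation of the target against heat), which sits at the top of the three numbers shown, yet the gaps to compound 1 `CC(C)(C)c1cc(NC(=O)Nc2ccc(Cl)cc2)n(-c2ccc(C(F)(F)F)cc2)n1` at 0.6 degrees C and to compound 3 `N#Cc1ccc(-n2nc(C3CC3)cc2NC(=O)Nc2ccc(Cl)cc2)cc1` at 0.5 degrees C both lie within the scatter, so no real order among them can be claimed. Compound 4 `CC(C)(C)c1cc(NC(=O)Nc2ccc(Cl)cc2)n(-c2ccc(N)cc2)n1` differs from compound 2 by amino in place of cyano on an aromatic carbon. Among the compounds with values here, two measured steps bear on this: a number 0.20 degrees C higher from compound 1 to compound 2 (within the scatter) exchanged one group at the same place, and a number 0.30 degrees C lower from compound 2 to compound 3 (within the scatter) altered another part of the shared core; both stayed within the scatter. Nothing seen so far therefore points to a change beyond the scatter in this assay, and the expected step is a number 0.20 degrees C lower from compound 2 to compound 4 (within the scatter). Compound 4 is estimated to give 0.6 degrees C, within a range from -0.4 degrees C to 1.6 degrees C.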

Compound 4, shift of the target's melting temperature: 2 degrees C
Estimate against measurement, compound 4: 1.4 degrees C below, and the stated range ends below it.
By their numbers in this assay, from the lowest: compounds 3, 1 and 2 (each within the scatter of the next); then compound 4.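

This place on the ring is not indifferent in this assay. Amino in place of cyano gives a number 1.2 degrees C higher from compound 2 to compound 4 (beyond the scatter), and amino in place of trifluoromethyl gives a number 1.4 degrees C higher from compound 1 to compound 4 (beyond the scatter), whereas cyano and trifluoromethyl had stayed within the scatter of each other. No measurement shown here explains what amino does at this place. Still open, as far as these compounds go, is whether a hydroxyl, a methylamino group or a carboxylic acid at this place would match amino, and whether amino keeps its step when cyclopropyl replaces tert-butyl.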